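Spiro-diamine ethers on HepG2: shifting the aryl ether substituent

The compounds below may be only part of what the source reports. "The series", "measured", "known", "first", "only" and "open" are said of these compounds alone.

The series is built around one shared core; compound 1 `NC1=NC2(CCSCC2)N(OCCCOc2cccc(Cl)c2)C(N)=N1` carries a 3-chlorophenyl ether and, in a functional assay on HepG2 cells (Homo sapiens) for antiproliferative activity, read by MTT assay, with a stated time of 72 h (on this read-out lower numbers stand for stronger inhibition and higher numbers for weaker inhibition), compound 1 gives 90 nM. Compound 2 `NC1=NC2(CCOCC2)N(OCCCOc2ccc(F)cc2)C(N)=N1` exchanges the sulfur-bearing ring of the core for an oxygen-bearing one and carries a 4-fluorophenyl ether; in this assay compound 2 gives "not determined" (no result reported), so compound 2 cannot be placed against compound 1. Compound 3 `NC1=NC2(CCOCC2)N(OCCCOc2cccc(Cl)c2Cl)C(N)=N1` follows from compound 2 by one change: 2,3-dichlorophenyl in place of 4-fluorophenyl on an oxygen on a saturated carbon. Among the compounds with values here, no measured step between neighbours exists in this set, so the expected size of the step from compound 2 to compound 3 cannot be taken from data; with two chlorines entering the aryl ether, as in the chlorinated aryl ether of compound 1, no step beyond the scatter is expected in either direction. Compound 3 is estimated at 150 nM, within 40 nM to 600 nM.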

Compound 3, half-maximal inhibitory concentration: 330 nM
Compound 3: the middle estimate sits 2.2-fold (0.34 log units) below what was measured; the range from low to high includes it.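

The step from compound 2 to compound 3 cannot be read: compound 2 has no single number in this assay, and compound 1 and compound 3 differ in more than one place. Going by these compounds, how 2,3-dichlorophenyl compares with 4-fluorophenyl on the shared core stays open, and no data here bear on the result.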